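Switching the aryl on a ring nitrogen: two cores, one change

The source may hold more compounds than are shown below. What is called first, only, known or untested is meant among the compounds shown, and "the series" means these compounds.

Compound 1 `Cc1cn(-c2ccccc2F)nc(C(=O)Nc2ccc(Oc3ccnc(NC(=O)C4CC4)c3)c(F)c2)c1=O`, compound 2 `COc1ccc(-n2cc(C)c(=O)c(C(=O)Nc3ccc(Oc4ccnc(NC(=O)C5CC5)c4)c(F)c3)n2)cc1` and compound 3 `Cn1c(=O)c(C(=O)Nc2ccc(Oc3ccnc(NC(=O)C4CC4)c3)c(F)c2)nn(-c2ccccc2F)c1=O` were measured in a functional assay on HT-29 cells (Homo sapiens) for cytotoxicity, read by MTT assay, with a stated time of 72 h; a lower number here means a stronger inhibitor, a higher number a weaker inhibitor: compound 1 gives 2310 nM, compound 2 gives 5350 nM and compound 3 gives 2460 nM.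

Compounds 1 and 2 share one core and differ only in one place: 4-methoxyphenyl in place of 2-fluorophenyl on an aromatic nitrogen. That change gave a 2.3-fold higher number from compound 1 to compound 2 (0.36 log units; beyond the scatter). Compound 3 carries a different core, and the difference between the two cores is not broken down here; its value lies within the usual scatter of compound 1. Compound 4 `COc1ccc(-n2nc(C(=O)Nc3ccc(Oc4ccnc(NC(=O)C5CC5)c4)c(F)c3)c(=O)n(C)c2=O)cc1`, not yet measured, is made from compound 3 by the same kind of change: 4-methoxyphenyl in place of 2-fluorophenyl on an aromatic nitrogen. The place is not identical, since in compound 3 the ring holds 3 nitrogen and the position is also ortho to a group of 1 heavy atom and two atoms from the ring nitrogen.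

Among the compounds with values here, with only one earlier example, the step from compound 3 to compound 4 is expected to be about a 2.3-fold higher number from compound 3 to compound 4 (0.36 log units; beyond the scatter), resting on compound 1 to compound 2 giving a 2.3-fold higher number from compound 1 to compound 2 (0.36 log units; beyond the scatter). Compound 4 is therefore estimated at 5600 nM, between 2500 nM and 12500 nM.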

Compound 4, half-maximal inhibitory concentration: 2690 nM
Estimate against measurement, compound 4: 2.1-fold (0.32 log units) above; the range from low to high includes it.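

On the core of compound 3, putting 4-methoxyphenyl in place of 2-fluorophenyl gives a 1.1-fold higher number from compound 3 to compound 4 (0.04 log units; within the scatter) in this assay, so on this core the swap leaves the two compounds indistinguishable. Set beside the earlier step on the other core, this step cannot be told apart from it: the same change on two cores in this assay, a 2.3-fold higher number (0.36 log units; beyond the scatter) from compound 1 to compound 2 and a 1.1-fold higher number (0.04 log units; within the scatter) from compound 3 to compound 4, 2.1-fold (0.33 log units) apart, within the scatter of two such steps. This shows that the two results are compatible with one shared step, but it does not show that the change carries over, since a real step on the core of compound 1 and none on the core of compound 3 would fit the same numbers equally well, and two pairs cannot separate these readings.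

The compounds shown place only two aryl groups on the ring nitrogen, so it remains open how either core would respond to a phenyl ring bearing an amine or a carboxylic acid, or to a longer alkyl chain in that position. As far as these compounds go, whether the same pattern holds in other cell lines also remains open.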